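A Methoxy Added to Compound 3: What to Expect

The source may hold more compounds than are shown below. What is called first, only, known or untested is meant among the compounds shown, and "the series" means these compounds.

Compound 1, `COc1ccc(-c2c(C)nn(-c3ccccc3)c2OC)c(OC)c1`, gives 39 ug/mL in a physicochemical assay, read by spectrophotometry, with a stated time of 30 min; a higher number here means a weaker inhibitor, a lower number a stronger inhibitor.
Compound 2, `COc1c(-c2csc3ccccc23)c(C)nn1-c1ccccc1`, gives 50.7 ug/mL in this assay.
Compound 3, `COc1c(C(=O)NCc2ccccc2)c(C)nn1-c1ccccc1`, gives 23.6 ug/mL in this assay.

Compound 3 holds the lowest of the three numbers in this assay. Compound 1 stands within the scatter of it, so no order between the two can be claimed, while compound 2 stands beyond the scatter above compound 3. Compound 4, `COc1ccc(CNC(=O)c2c(C)nn(-c3ccccc3)c2OC)cc1`, has not yet been measured. It differs from compound 3 in a single place: methoxy in place of hydrogen on an aromatic carbon. Within the data shown here, no step between measured compounds resembles this change, so there is nothing among the measured compounds to anchor its size. The step of a 1.1-fold lower number from compound 3 to compound 4 (0.03 log units; within the scatter) is expected to be small, no further than the usual scatter, in either direction. Compound 4 is therefore expected to give about 22 ug/mL, with a range from 10 ug/mL to 50 ug/mL.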

Compound 4, half-maximal inhibitory concentration: 28.4 ug/mL
Compound 4: middle estimate off by 1.3-fold (0.11 log units), on the low side; the range from low to high includes it.
By their numbers in this assay, from the lowest: compounds 3, 4, 1 and 2 (each within the scatter of the next, the first and the last beyond it).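

In this assay, methoxy in place of hydrogen on an aromatic carbon, para to a large group, gives a 1.2-fold higher number from compound 3 to compound 4 (0.08 log units; within the scatter) and so leaves compound 3 and compound 4 without an order. Among these compounds, this is the first measured step at this position, and it shows that phenyl to 4-methoxyphenyl here does not move the number past what repeated measurements alone would give. Nothing measured bears on why this is so.

From the compounds shown here alone, whether an amine or a carboxylic acid at this same place would move the number beyond the scatter stays open. So does whether methoxy elsewhere on this ring would behave alike.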